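Methyl on the benzylic carbon in a quinolinone amine series

The source may hold more compounds than are shown below. What is called first, only, known or untested is meant among the compounds shown, and "the series" means these compounds.

Compound 1 `COCOc1ccc(CN(Cc2ccc(C(C)(C)C)cc2)Cc2cc3cc(C)ccc3[nH]c2=O)cc1` gives 6400 nM in a toxicity assay on MDCK cells (Canis lupus familiaris) for cytotoxicity, read by crystal violet staining, with a stated time of 48 h; on this read-out higher numbers stand for lower toxicity in this test and lower numbers for higher toxicity in this test. Compound 2 `CCc1ccc2[nH]c(=O)c(CN(Cc3ccc(OCOC)cc3)Cc3ccc(C(C)(C)C)cc3)cc2c1` carries methyl in place of hydrogen on a saturated chain carbon bound to an aromatic carbon relative to compound 1. In this assay compound 2 gives a limit of the assay, > 10000 nM, so the step of an at least 1.5-fold higher number from compound 1 to compound 2 (0.19 log units; that floor lies within the scatter) is bounded only on one side, resting on (the limit of > 10000 nM in this assay, at which 1 of the 3 values shown sits). Compound 3 `Cc1ccc2[nH]c(=O)c(CN(Cc3ccc(C(C)(C)C)cc3)C(C)c3ccc(OC(F)F)cc3)cc2c1` differs from compound 1 by 1-(4-(difluoromethoxy)phenyl)ethyl in place of 4-(methoxymethoxy)benzyl on an amine nitrogen. In this assay compound 3 likewise gives a limit, > 5000 nM; the step that the limit leaves unreadable from compound 1 to compound 3 therefore cannot be sized, which rests on (the limit of > 5000 nM in this assay, at which 1 of the 3 values shown sits).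

Compound 4 `CCc1ccc2[nH]c(=O)c(CN(Cc3ccc(C(C)(C)C)cc3)C(C)c3ccc(OC(F)F)cc3)cc2c1` is not yet measured. Against compound 3 it shows (methyl in place of hydrogen on a saturated chain carbon bound to an aromatic carbon), the same change as from compound 1 to compound 2, at the same place. The earlier instance moved the number upward from compound 1 to compound 2, though its floor lies within the scatter, and compound 3 already sits at a limit. A step that the limit leaves unreadable from compound 3 to compound 4 is expected from compound 3 to compound 4 on that basis, with the outcome likely to be reported again as a limit. Compound 4 is estimated at 12000 nM in this assay, between 6000 nM and 30000 nM.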

Compound 4, half-maximal cytotoxic concentration: > 5000 nM
Compound 4: a limit, no number; the forecaster's own chance of this, stated with the estimate: 70%; the middle value is on the limit's open side.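

Compound 2, compound 3 and compound 4 all stand at limits of the assay, and no new step can be read from compound 3 to compound 4 or from compound 2 to compound 4: the limit of > 5000 nM in this assay, at which 2 of the 4 values shown sit. The compounds shown leave open whether methyl in place of hydrogen on a saturated chain carbon bound to an aromatic carbon shifts the number in this assay at all.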